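Ether oxygen in the chain of compound 3

The compounds below may be only part of what the source reports. "The series", "measured", "known", "first", "only" and "open" are said of these compounds alone.

Measured compounds: compound 1, `O=C1N=C(O)S/C1=C\c1ccc(OCCC2CCCCC2)cc1Cl`, 13 nM; compound 2, `CC(C)OCCOc1ccc(/C=C2\SC(=O)NC2=O)c(Cl)c1`, 1050 nM; compound 3, `O=C1NC(=O)/C(=C/c2ccc(OCCC3CCCC3)cc2Cl)S1`, 42 nM.

In an assay for inhibition of 15-hydroxyprostaglandin dehydrogenase [NAD(+)] (Homo sapiens), read by fluorescence and spectrophotometry (a lower number here means a stronger inhibitor, a higher number a weaker inhibitor), compound 3 stands second of the three, between compound 1 and compound 2. The next compound, compound 4, `O=C1NC(=O)/C(=C/c2ccc(OCCOC3CCCCC3)cc2Cl)S1`, changes the chain end: cyclohexyloxy in place of cyclopentyl on a saturated chain carbon, two bonds along the chain from an oxygen on an aromatic ring. Going by the values given here, one measured step bears on this: a 25-fold lower number from compound 2 to compound 3 (1.40 log units; beyond the scatter), where an isopropoxy group gave way to a ring of carbon only. Compound 4 reverses part of that move, putting an oxygen back into the chain, but keeps a ring at the end, as compound 1 does with its cyclohexyl; compound 1 gives the lowest number of the three and compound 3 sits somewhat above it. The change is therefore expected to move compound 4 toward compound 2, yet not all the way, and the step of a 2.6-fold higher number from compound 3 to compound 4 (0.42 log units; beyond the scatter) is the estimated result. For compound 4 the expected value in this assay is 110 nM, within a range from 30 nM to 450 nM.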

Compound 4, half-maximal inhibitory concentration: 211 nM
The estimate for compound 4 lay 1.9-fold (0.28 log units) below the measured number, and the stated range covers the measured number.
By their numbers in this assay, from the lowest: compound 1; then compound 3; then compound 4; then compound 2.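

The chain oxygen is tolerated at a price in this assay: cyclohexyloxy in place of cyclopentyl gives a 5.0-fold higher number from compound 3 to compound 4 (0.70 log units; beyond the scatter) and so loses part of what the all-carbon chain end gained. With the oxygen kept in the chain, the ring end still helps, since cyclohexyl in place of isopropyl on an oxygen on a saturated carbon gives a 5.0-fold lower number from compound 2 to compound 4 (0.70 log units; beyond the scatter), so the earlier gain from isopropoxy to cyclopentyl did not depend only on removing that oxygen. Nothing available here accounts for either step.

The compounds shown leave open how much of the rise from compound 3 belongs to the oxygen and how much to the larger ring, a split that a cyclopentyloxy group at this place would address. Also open, on these data alone, is how an amine in place of the ether oxygen would read in this assay.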